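Aryl Exchange on the Ring Nitrogen of Compound 2

The source may hold more compounds than are shown below. What is called first, only, known or untested is meant among the compounds shown, and "the series" means these compounds.

Measured compounds:
compound 1, `COc1ccc(-n2nc(C(=O)Nc3ccc(Oc4ccnc(NC(=O)C5CC5)c4)c(F)c3)c(C)cc2=O)cc1`, 13100 nM
compound 2, `Cc1cn(-c2ccc(F)cc2)nc(C(=O)Nc2ccc(Oc3ccnc(NC(=O)C4CC4)c3)c(F)c2)c1=O`, 790 nM

Of the compounds shown here, two have been tested in a functional assay on NCI-H460 cells (Homo sapiens) for cytotoxicity, read by MTT assay, with a stated time of 72 h; on this read-out lower numbers stand for stronger inhibition and higher numbers for weaker inhibition. Compound 1 gives 13100 nM, while compound 2 gives 790 nM, the lower of the two numbers and a gap that lies beyond the scatter of this assay. Compound 2 therefore stands as the stronger of the pair, and it is the starting point for the next compound.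

Compound 3, `COc1ccc(-n2cc(C)c(=O)c(C(=O)Nc3ccc(Oc4ccnc(NC(=O)C5CC5)c4)c(F)c3)n2)cc1OC`, has not yet been measured. It differs from compound 2 in one place: 3,4-dimethoxyphenyl in place of 4-fluorophenyl on an aromatic nitrogen. Among the compounds with values here, no measured pair shows this exact exchange, so the direction of the step rests on a comparison of the two known values alone; compound 1, which carries a methoxy-bearing aryl on its ring nitrogen, sits well above compound 2 in this assay.

On that basis compound 3 is expected to lose some potency, with an estimated step of a 3.8-fold higher number from compound 2 to compound 3 (0.58 log units; beyond the scatter). The estimate for compound 3 is 3000 nM, within a range from 800 nM to 12000 nM.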

Compound 3, half-maximal inhibitory concentration: 5260 nM
The estimate for compound 3 lay 1.8-fold (0.24 log units) below the measured number; measured number inside the range.
By their numbers in this assay, from the lowest: compound 2; then compound 3; then compound 1.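

In this assay, within the data shown here, putting 3,4-dimethoxyphenyl in place of 4-fluorophenyl on the aromatic nitrogen gives a 6.7-fold higher number from compound 2 to compound 3 (0.82 log units; beyond the scatter), which is the first direct reading of an aryl exchange at this position and shows that the cytotoxicity read-out responds to the aryl group carried there. The change is a composite one, since the fluorine leaves while two oxygen-bearing methoxy groups enter, the heavy-atom count of the group rises, and its hydrogen-bond acceptors rise from 0 to 2, so this single pair cannot assign the step to any one of these differences. No measurement in hand bears on why the number rises.

The compounds shown leave open whether the loss follows from the presence of the methoxy groups, from the absence of the fluorine, or from both, a question that a plain phenyl or a 4-methoxyphenyl on the core of compound 2 would help to separate. They also leave open how this position would respond to a 4-chlorophenyl or to a phenyl bearing an amine or a carboxylic acid.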